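Allyl to trifluoroethyl ester: expected loss of growth inhibition

The compounds below may be only part of what the source reports. "The series", "measured", "known", "first", "only" and "open" are said of these compounds alone.

Going by the values given here, in a functional assay on HeLa cells (Homo sapiens) for inhibition (on this read-out lower numbers stand for stronger inhibition of growth and higher numbers for weaker inhibition of growth), compound 3 `C=CCOC(=O)c1ccsc1NC(=O)[C@@H]1CCCN1` gives 94.9 ug/mL as the only true number of the series. Compound 1 `O=C(Oc1ccccc1)c1ccsc1NC(=O)[C@@H]1CCCN1` stands at > 250 ug/mL as a limit of the assay. Compound 2 `O=C(OCC(Cl)(Cl)Cl)c1ccsc1NC(=O)[C@@H]1CCCN1` stands at > 250 ug/mL as a limit too.

Compound 4 `O=C(OCC(F)(F)F)c1ccsc1NC(=O)[C@@H]1CCCN1` has trifluoromethyl in place of vinyl on a saturated chain carbon bound to an oxygen next to a carbonyl group. Compound 2 is the closest measured relative, and its change to vinyl gave an at least 2.6-fold lower number from compound 2 to compound 3 (0.42 log units; beyond the scatter) as a step. The change from phenyl gave an at least 2.6-fold lower number from compound 1 to compound 3 (0.42 log units; beyond the scatter) in the same direction.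

A modest step to a higher number, meaning weaker inhibition, is therefore expected in this assay and estimated as a 1.8-fold higher number from compound 3 to compound 4 (0.25 log units; within the scatter) here. The estimated value for compound 4 is 170 ug/mL with an expected range from 80 ug/mL to 350 ug/mL in this read-out.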

Compound 4, concentration for 50% growth inhibition: 109 ug/mL
For compound 4 the middle estimate is 1.6-fold (0.19 log units) above the measured one, within the range that was stated.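

In this assay, trifluoromethyl on a saturated chain carbon bound to an oxygen next to a carbonyl group gives a second true number in the series, and replacing vinyl there gives a 1.1-fold higher number from compound 3 to compound 4 (0.06 log units; within the scatter). A halogenated group at this place therefore does not by itself bring the value to the limit, with trichloromethyl giving an at least 2.2-fold lower number from compound 2 to compound 4 (0.36 log units; beyond the scatter) and the phenyl ester giving an at least 2.2-fold lower number from compound 1 to compound 4 (0.36 log units; beyond the scatter). These two steps start from limits, not numbers: the limit of > 250 ug/mL in this assay, at which 2 of the 4 values shown sit.

As far as these compounds go, their full sizes stay open, and the step between compound 1 and compound 2 cannot be read. From the compounds shown here alone, whether an amine or a longer chain at this place would give a value beyond the scatter of compound 3 also stays open.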